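Compound 2 to compound 4: acetyl to methoxycarbonyl

The compounds below may be only part of what the source reports. "The series", "measured", "known", "first", "only" and "open" are said of these compounds alone.

Of the compounds shown here, three have been read in an ADME assay on HEK293 cells (Homo sapiens) for cytotoxicity, with a stated time of 72 h (a lower number here means that less compound is needed, a higher number that more compound is needed for the effect), so far. Compound 1 `Cc1cc(NC(=O)Nc2ccc(Cl)c(Cl)c2)c2ccccc2n1` gives > 25000 nM as a limit of the assay. Compound 2 `CC(=O)c1ccc(NC(=O)Nc2cc(C)nc3ccccc23)cc1` gives > 25000 nM as a limit too. Compound 3 `Cc1cc(NC(=O)Nc2cccc(C(N)=O)c2)c2ccccc2n1` gives > 25000 nM as a limit as well. Compound 2 therefore carries no number of its own and stands at the limit of > 25000 nM in this assay, at which 3 of the 3 values shown sit, like the others.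

Compound 4 `COC(=O)c1ccc(NC(=O)Nc2cc(C)nc3ccccc23)cc1` has methoxy in place of methyl on a carbonyl carbon and keeps the rest of compound 2. For the measured compounds named here, no measured step is available as a guide. The expected step that the limit leaves unreadable from compound 2 to compound 4 is none beyond the scatter, in either direction. Compound 4 is estimated at 30000 nM within an expected range of 12000 nM to 60000 nM for now.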

Compound 4, half-maximal effective concentration: 15000 nM
For compound 4 the middle estimate is 2.0-fold (0.30 log units) above the measured one, and the stated range covers the measured number.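

Among the four compounds shown, only compound 4 gives a number rather than a limit in this assay, with 15000 nM. On this carbonyl carbon, methoxy in place of methyl gives an at least 1.6-fold lower number from compound 2 to compound 4 (0.22 log units; that floor lies within the scatter). The true size of the step stays unknown, since the value of compound 2 is only a limit: the limit of > 25000 nM in this assay, at which 3 of the 4 values shown sit.

Open, as far as these compounds go, is whether a real difference separates compound 4 from compound 2 in this assay. Also open, from the compounds shown here alone, is how a carboxylic acid or a longer chain such as ethoxycarbonyl would read in place of methoxycarbonyl.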